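Working notes: tolerated concentration across three aromatic substitution variants

The compounds below may be only part of what the source reports. "The series", "measured", "known", "first", "only" and "open" are said of these compounds alone.

Measured so far in an ADME assay on HEL cells (Homo sapiens) for cytotoxicity, read by microscopy; a lower number here means that less compound is tolerated, a higher number that more compound is tolerated:
compound 1 `O=c1ccn(CCCCCOc2ccc(Cl)cc2)c(=O)[nH]1` — > 100000 nM
compound 2 `O=c1ccn(CCCCCOc2ccc([N+](=O)[O-])cc2)c(=O)[nH]1` — 20000 nM

Compound 1 stands at a limit of this assay, its value being > 100000 nM (the limit of > 100000 nM in this assay, at which 1 of the 2 values shown sits). Among the compounds with values here, compound 2 gives 20000 nM, so the one measured step, an at least 5.0-fold lower number from compound 1 to compound 2 (0.69 log units; beyond the scatter), shows that placing the nitro where the chloro stood brings the tolerated concentration down into the measurable range.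

Compound 3 `Cc1cccc(OCCCCCn2ccc(=O)[nH]c2=O)c1` is the next member to be read. Relative to compound 1 it carries 3-methylphenyl in place of 4-chlorophenyl on an oxygen on a saturated carbon. Within the data shown here, the only measured step concerns the nitro in place of chloro, a change of a different kind, and it cannot be applied directly here; no step in hand swaps the chloro for a methyl or changes which carbon of the ring the substituent sits on. With compound 1 at the limit and nothing pointing the other way, compound 3 is expected to remain at or close to that limit, the step of a number no higher from compound 1 to compound 3 (the limit leaves the size open) being the expectation. The estimate for compound 3 is therefore 100000 nM, within 30000 nM to 300000 nM, pending the reading in this assay.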

Compound 3, minimum cytotoxic concentration: > 100000 nM
Compound 3: a limit, no number (the forecaster's own chance of this, stated with the estimate: 65%); the middle value sits exactly at the limit.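

In this assay compound 3 gives > 100000 nM, which is a limit and not a number. Within the data shown here, compound 1 also stands at a limit, so no step between compound 1 and compound 3 can be read. The compounds shown leave open whether 3-methylphenyl in place of 4-chlorophenyl changes the tolerated concentration at all.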